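A few compounds are considered here, and "the series" means these few. Any claim that something is new, unique, unknown or untested is made for them only; others in the source may bear on it.

Compound 1 `Nc1scc(CN2CCN(c3ccc(F)cc3F)CC2)c1C(=O)c1ccc(Cl)cc1`: -82%
Compound 2 `Nc1scc(CN2CCN(c3cc(F)ccc3F)CC2)c1C(=O)c1ccc(Cl)cc1`: -80%

Both were run in a functional assay on CHO cells with adenosine receptor A1 (Homo sapiens) as the target, read by cAMP accumulation and immunoassay, with a stated time of 6 min, tested at 10 uM; a lower number here means a stronger effect, a higher number a weaker effect of the compound at the concentration tested. On these two numbers compound 2 stands highest, with compound 1 nearest: a number 2 percentage points higher from compound 1 to compound 2 (within the scatter). Compound 3 `Nc1scc(CN2CCN(c3c(F)cc(F)cc3F)CC2)c1C(=O)c1ccc(Cl)cc1` differs from compound 2 by 2,4,6-trifluorophenyl in place of 2,5-difluorophenyl on an amine nitrogen in a ring. For the measured compounds named here, the one step in hand, a number 2 percentage points higher from compound 1 to compound 2 (within the scatter), also exchanged one fluorophenyl for another on the same amine nitrogen in a ring and stayed within the scatter, so no step beyond the scatter is expected in this assay here either. Compound 3 is therefore estimated at -80%, range -92% to -64%. The expected step is no change at the digits printed from compound 2 to compound 3 (within the scatter).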

Compound 3, a percentage reported as activity, at one concentration (the size of the read-out at that concentration, not a potency): -78%
For compound 3 the middle estimate is 2 percentage points below the measured one; measured number inside the range.
By their numbers in this assay, from the lowest: compounds 1, 2 and 3 (each within the scatter of the next).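

In this assay the 2,4,6-trifluorophenyl group gives a number 2 percentage points higher from compound 2 to compound 3 (within the scatter) and, read as fluoro in place of hydrogen on an aromatic carbon, a number 4 percentage points higher from compound 1 to compound 3 (within the scatter). For the compounds shown here, a third fluorine on the aromatic ring at this amine nitrogen in a ring therefore leaves the read-out within the scatter of both difluorophenyl compounds, with no compound in the set going against this. No measurement here bears on the reason for this. Open, from the compounds shown here alone, is whether the position holds this read-out with an unsubstituted phenyl, a methoxyphenyl or a pyridine ring in place of the fluorophenyl groups.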